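The source may report more compounds than this note shows. Statements on the series, on what has been measured and on what is new or still open speak of the compounds shown alone.

Compound 1, with the structure `CC1=CC[C@H](C(C)(C)NC(=S)NN)CC1`, carries the shared core with a free thiosemicarbazide end. In a functional assay on 786-0 cells (Homo sapiens) for inhibition, read by sulforhodamine B assay, with a stated time of 48 h (a higher number here means a weaker inhibitor of growth, a lower number a stronger inhibitor of growth), compound 1 gives only a limit of the assay, > 100000 nM, and no number. Compound 2, with the structure `CC1=CC[C@H](C(C)(C)NC(=S)N/N=C/c2ccccc2O)CC1`, extends that end into a hydrazone bearing a 2-hydroxyphenyl group, and in this assay compound 2 gives 12100 nM. On the numbers shown, compound 2 holds the only measured value, the other entry being a limit, as stated in the limit of > 100000 nM in this assay, at which 1 of the 2 values shown sits.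

Compound 3, with the structure `CC1=CC[C@H](C(C)(C)NC(=S)N/N=C/c2ccco2)CC1`, differs from compound 2 in one place: furan-2-yl in place of 2-hydroxyphenyl on a carbon with a double bond to nitrogen. Going by the values given here, no measured step of this kind is available, so the size of the step can only be estimated. The step from compound 2 to compound 3 is expected to be a modest loss, a 2.5-fold higher number from compound 2 to compound 3 (0.39 log units; beyond the scatter), somewhat beyond the scatter but not large. Compound 3 is therefore estimated at 30000 nM in this assay, with a range from 8000 nM to 100000 nM.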

Compound 3, concentration for total growth inhibition: 9800 nM
The estimate for compound 3 lay 3.1-fold (0.49 log units) above the measured number; low and high end bracket the measured number.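

In this assay, furan-2-yl takes the place of 2-hydroxyphenyl on the carbon with a double bond to nitrogen with a 1.2-fold lower number from compound 2 to compound 3 (0.09 log units; within the scatter), so at this place neither the six-membered aromatic ring of carbon only nor the hydrogen-bond donor of the leaving group is needed to keep the growth inhibition seen with compound 2. The gain over the free thiosemicarbazide end of the shared core now rests on two different aromatic groups rather than one, and the step for the furan-2-yl hydrazone reads an at least 10-fold lower number from compound 1 to compound 3 (1.00 log units; beyond the scatter). That step is bounded on one side only, since compound 1 gives a limit of the assay and not a number: the limit of > 100000 nM in this assay, at which 1 of the 3 values shown sits.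

From the compounds shown here alone, what a methyl group, a cyclohexyl group or a pyridine ring would do at this place remains open, so it cannot be said whether an aromatic ring is needed here at all. Both groups shown also carry an oxygen atom, and a plain phenyl group or a thiophene ring would be needed to tell whether that oxygen plays any part.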